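The source may report more compounds than this note shows. Statements on the series, on what has been measured and on what is new or still open speak of the compounds shown alone.

Compound 1: `COc1cccc(OC)c1C(=O)Nc1nnc(-c2ccc(F)cc2)s1` with 3.5
Compound 2: `COc1cccc(OC)c1C(=O)Nc1nnc(-c2ccc([N+](=O)[O-])cc2)s1` with 2.54

Both were measured in a physicochemical assay for lipophilicity, measured as octanol-water partition; a higher number here means a more lipophilic compound, a lower number a more polar compound. Going by the values given here, compound 2 holds the lower of the two numbers, and the one measured step, a number 0.96 log units lower from compound 1 to compound 2 (beyond the scatter), puts it beyond the scatter below compound 1. Compound 3, `COc1cccc(OC)c1C(=O)Nc1nnc(-c2ccc(C#N)cc2)s1`, has not been measured yet. It differs from compound 2 in a single place: cyano in place of nitro on an aromatic carbon. The measured step concerns the same place on the ring but exchanges fluoro for nitro, not nitro for cyano, so it bears on the present change only indirectly: it shows that a swap at this place can move the number by a modest amount, yet it does not fix the direction of this particular swap. The estimated change is therefore small, a number 0.24 log units lower from compound 2 to compound 3 (within the scatter), and may well stay within the scatter. For compound 3 the expected value in this assay is 2.3, with a range from 1.9 to 2.7.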

Compound 3, partition coefficient: 3.14
Compound 3: middle estimate off by 0.84 log units, on the low side; the whole stated range lies below it.
By their numbers in this assay, from the lowest: compound 2; then compound 3; then compound 1.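

In this assay, going from 4-nitrophenyl to 4-cyanophenyl gives a number 0.60 log units higher from compound 2 to compound 3 (beyond the scatter), so exchanging these two groups at this position produces a real difference rather than one lost in the scatter. The nitrile also stands apart from the fluoro group, with a number 0.36 log units lower from compound 1 to compound 3 (beyond the scatter). Among these three compounds, the groups at this one place therefore fall into a clear order: nitro lowest, cyano in the middle and fluoro highest.

Nothing available here explains why the three groups fall in this order. On these data alone, it remains open whether an amine, a carboxylic acid or a methyl group at this position would fall within this range or outside it, and whether the same order would hold on a different core.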